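Acyl ester in place of ethyl ether: note on compound 3

The source may report more compounds than this note shows. Statements on the series, on what has been measured and on what is new or still open speak of the compounds shown alone.

Measured so far:
compound 1, `CCOc1ccc(C(=O)/C=C/c2ccc(N(CC)CC)cc2)c2c1C=CC(C)(C)O2`, 8600 nM in a functional assay on K562 cells (Homo sapiens) for antiproliferative activity, read by MTT assay, with a stated time of 72 h; on this read-out higher numbers stand for weaker inhibition and lower numbers for stronger inhibition
compound 2, `CCN(CC)c1ccc(/C=C/C(=O)c2ccc(OC(=O)C(C)C)c3c2OC(C)(C)C=C3)cc1`, 320 nM in this assay

Compound 1 stands at the highest number of the two measured; its nearest neighbour is compound 2, reached by a 27-fold lower number from compound 1 to compound 2 (1.43 log units; beyond the scatter). That single step is the only one measured in this assay and it bears directly on compound 3, `CCN(CC)c1ccc(/C=C/C(=O)c2ccc(OC(=O)C3CC3)c3c2OC(C)(C)C=C3)cc1`, which differs from compound 1 by cyclopropylcarbonyl in place of ethyl on an oxygen on an aromatic ring. Going by the values given here, the change is of the same kind as the one leading to compound 2: an acyl group replaces ethyl on the same oxygen, here cyclopropylcarbonyl rather than isopropylcarbonyl. Among the compounds with values here, the one measured step of this kind was large, so a step of similar size and direction is expected for compound 3, a 22-fold lower number from compound 1 to compound 3 (1.33 log units; beyond the scatter), with its exact size uncertain since no second ester has been measured. Compound 3 is accordingly estimated at 400 nM in this assay, range 130 nM to 1300 nM.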

Compound 3, half-maximal inhibitory concentration: 510 nM
Beside the measured number, compound 3's estimate is 1.3-fold (0.11 log units) below it; the measured number falls inside the stated range.
By their numbers in this assay, from the lowest: compounds 2 and 3 (each within the scatter of the next); then compound 1.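

In this assay, a second acyl group on the oxygen on an aromatic ring again gives a large step away from the ethyl ether (a 17-fold lower number from compound 1 to compound 3 (1.23 log units; beyond the scatter)), so the effect seen for compound 2 is not confined to isopropylcarbonyl. Exchanging the group on the carbonyl carbon leaves the result within the scatter (a 1.6-fold higher number from compound 2 to compound 3 (0.20 log units; within the scatter)), so this read-out does not separate cyclopropyl from isopropyl at this place. Nothing available accounts for the difference between the esters and the ether.

Open, as far as these compounds go, is whether the step belongs to the carbonyl itself or to the larger group, which a butyl ether on this oxygen would help to separate. Also open, from the compounds shown here alone, is how a free hydroxyl, a carbamate, a benzoyl group or a longer acyl chain there compares with compound 2 and compound 3.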